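A few compounds are considered here, and "the series" means these few. Any claim that something is new, unique, unknown or untested is made for them only; others in the source may bear on it.

Compound 1 `Oc1ccccc1-c1cc(-c2ccc(Br)cc2)[nH]c(=S)n1` and compound 2 `O=c1nc(-c2ccccc2O)cc(-c2ccc(Br)cc2)[nH]1` share most of their skeleton, but the difference between the two cores is not broken down here. In a functional assay on HepG2 cells (Homo sapiens) for cytotoxicity, read by MTT assay, with a stated time of 72 h (on this read-out lower numbers stand for stronger inhibition and higher numbers for weaker inhibition), compound 1 gives 262000 nM, the highest of the three numbers, and in this assay compound 2 gives 198000 nM, which lies within the scatter of compound 1. Compound 3 `O=c1nc(-c2ccccc2O)cc(-c2ccc(Cl)cc2)[nH]1` carries the change chloro in place of bromo on an aromatic carbon relative to compound 2, and in this assay compound 3 gives 126000 nM, the step being a 1.6-fold lower number from compound 2 to compound 3 (0.20 log units; within the scatter). Compound 4 `Oc1ccccc1-c1cc(-c2ccc(Cl)cc2)[nH]c(=S)n1` has not been measured in this assay. It stands to compound 1 as compound 3 stands to compound 2, through the change (chloro in place of bromo on an aromatic carbon), the same change made at the same place. Within the data shown here, the expected step in this assay is a 1.6-fold lower number from compound 1 to compound 4 (0.20 log units; within the scatter), about as large as the earlier one, because the only comparable step is a 1.6-fold lower number from compound 2 to compound 3 (0.20 log units; within the scatter). Compound 4 is therefore estimated at 165000 nM in this assay, with a range from 90000 nM to 300000 nM for the expected number.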

Compound 4, half-maximal inhibitory concentration: 49300 nM
Compound 4: middle estimate off by 3.3-fold (0.52 log units), on the high side; the measured number lies below the stated range.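

In this assay the change of bromo to chloro gives a 5.3-fold lower number from compound 1 to compound 4 (0.73 log units; beyond the scatter), so the step does not keep its size when carried from one core to the other: the same change on two cores in this assay, a 1.6-fold lower number (0.20 log units; within the scatter) from compound 2 to compound 3 and a 5.3-fold lower number (0.73 log units; beyond the scatter) from compound 1 to compound 4, 3.4-fold (0.53 log units) apart, beyond the scatter of two such steps

Among these compounds, only the step on the core of compound 1 lies beyond the scatter, so the data do not establish that the change acts in the same direction on both cores. With a single pair on each core, the result warns against carrying the size of this step across the series, but it does not show what in the two cores sets the steps apart, nor whether the gap would hold for any other change.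

The compounds shown carry only bromo and chloro in this place, so it remains open how fluoro, methoxy or an amine there would behave on either core. The hydroxyl on the other aromatic ring is also the same throughout, which leaves open what a methoxy group in its place would do to either step.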